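Compound 1 to compound 4: fluoro replaced by methoxy

The source may report more compounds than this note shows. Statements on the series, on what has been measured and on what is new or still open speak of the compounds shown alone.

Measured so far in a functional assay on DU-145 cells (Homo sapiens) for inhibition, read by trypan blue exclusion, with a stated time of 96 h (on this read-out lower numbers stand for stronger inhibition of growth and higher numbers for weaker inhibition of growth), are:
- compound 1 `O=C(/C(=C\c1ccccc1OCc1ccccc1)S(=O)(=O)c1ccc(F)cc1)c1ccc(Cl)cc1` with 1000 nM
- compound 2 `O=C(/C(=C/c1ccc(O)c([N+](=O)[O-])c1)SCc1ccc(Br)cc1)c1ccc([N+](=O)[O-])c(Cl)c1` with 1000 nM
- compound 3 `COc1ccc(/C=C(\C(=O)c2ccc(Br)cc2)S(=O)(=O)c2ccc(C)cc2)cc1` with 1000 nM

Compound 1 (1000 nM) stands level with compound 2 (1000 nM) and compound 3 (1000 nM), so the three structures give the same reading at the digits shown. Among the measured compounds shown here, none of the three separates from the others, and no pair of them differs in one place only. For the measured compounds named here, the series therefore offers no measured step to serve as a guide.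

The next compound, compound 4 `COc1ccc(S(=O)(=O)/C(=C/c2ccccc2OCc2ccccc2)C(=O)c2ccc(Cl)cc2)cc1`, keeps the core of compound 1 and changes one group. Methoxy stands in place of fluoro on an aromatic carbon, para to a large group, so that 4-fluorophenyl becomes 4-methoxyphenyl: methoxy in place of fluoro on an aromatic carbon.

The data do not show what this exchange does on its own. Going by the values given here, the only guide is the flat reading across compound 1 (1000 nM) and its two structurally different neighbours. No step beyond the scatter is expected, and neither direction is favoured. The expected result is no change at the digits printed from compound 1 to compound 4 (within the scatter) in this assay and would lie within the scatter. The estimated value for compound 4 is 1000 nM (expected range 350 nM to 2800 nM).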

Compound 4, concentration for 50% growth inhibition: 1000 nM
Compound 4: middle estimate and measured number agree at the digits printed, within the range that was stated.
By their numbers in this assay, from the lowest: compounds 1, 2, 3 and 4 (each within the scatter of the next).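

In this assay, methoxy in place of fluoro on an aromatic carbon, para to a large group, gives no change at the digits printed from compound 1 to compound 4 (within the scatter). Among the compounds shown here, until now the flat reading came only from compounds that differ in several places; this is the first comparison that isolates one position, the (4-fluorophenyl)sulfonyl to (4-methoxyphenyl)sulfonyl exchange, and at this read-out the position accepts both groups with no step beyond the scatter. No available evidence bears on why the two groups read alike, so the result stands as an observation about this pair alone.

The compounds shown leave open whether any group at this position separates from fluoro and methoxy in this assay, for example an amine, a carboxylic acid or a longer alkoxy chain such as butoxy. They also leave open whether the same exchange would read alike on a different core, since a single pair gives no basis for a rule that reaches beyond compound 1 and compound 4.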